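Chloro on the Styryl Ring in Two Enone Cores

The source may hold more compounds than are shown below. What is called first, only, known or untested is meant among the compounds shown, and "the series" means these compounds.

Measured compounds:
- compound 1, `CC(=O)OC/C(=C\c1ccc(Cl)cc1)C(=O)c1ccccc1`: 5300 nM
- compound 2, `CC(=O)OC/C(=C\c1ccc(Cl)cc1)C(=O)c1ccc(Cl)cc1`: 5400 nM
- compound 3, `C=C(C/C(=C\c1ccccc1)C(=O)c1ccccc1)C(=O)c1ccccc1`: 15000 nM

All three compounds were tested in a functional assay on T47D cells (Homo sapiens) for inhibition, read by sulforhodamine B assay, with a stated time of 48 h; on this read-out higher numbers stand for weaker inhibition of growth and lower numbers for stronger inhibition of growth. Compound 1 and compound 2 share one core; compound 2 differs from compound 1 by chloro in place of hydrogen on an aromatic carbon. This change made a 1.0-fold higher number from compound 1 to compound 2 (0.01 log units; within the scatter), so within this pair adding the chloro left the read-out essentially unchanged. Compound 3 is built on a different core, and the difference between the two cores is not broken down here. In this assay compound 3 gives the highest of the three numbers, and its gaps to both compound 1 and compound 2 lie beyond the usual scatter.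

Compound 4, `C=C(C/C(=C\c1ccc(Cl)cc1)C(=O)c1ccccc1)C(=O)c1ccccc1`, has not yet been measured. It differs from compound 3 by chloro in place of hydrogen on an aromatic carbon. The place is described in the same words as for the change from compound 1 to compound 2, so this is the same change, now made on the core of compound 3. Because the step of a 1.0-fold higher number from compound 1 to compound 2 (0.01 log units; within the scatter) stayed within the scatter, a step of similar size is expected on the second core. The step expected is no change at the digits printed from compound 3 to compound 4 (within the scatter). For compound 4 the estimated value in this assay is 15000 nM, with a range expected from 7000 nM to 32000 nM.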

Compound 4, concentration for 50% growth inhibition: 19000 nM
Estimate against measurement, compound 4: 1.3-fold (0.10 log units) below, within the range that was stated.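

In this assay, the change from phenyl to 4-chlorophenyl on the core of compound 3 gave a 1.3-fold higher number from compound 3 to compound 4 (0.10 log units; within the scatter), so this second example of the chloro-for-hydrogen swap also stays inside the normal spread of repeat measurements. Set side by side, the two examples agree: the same change on two cores in this assay, a 1.0-fold higher number (0.01 log units; within the scatter) from compound 1 to compound 2 and a 1.3-fold higher number (0.10 log units; within the scatter) from compound 3 to compound 4, 1.2-fold (0.09 log units) apart, within the scatter of two such steps. This shows that, on these two cores and in this one cell assay, the swap had no readable effect on the growth-inhibition number, but two pairs are too few to make a rule for other cores or other cell lines, and the numbers do not explain why the swap leaves the read-out where it was.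

The compounds shown leave open whether a different group in place of that hydrogen, such as a methoxy group, an amine or a carboxylic acid, would give a step beyond the scatter. They also leave open whether chloro would behave the same way on other aromatic carbons of these structures, and whether the smaller fluoro or the larger bromo would match it.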